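Dichlorobenzyl series: tert-butyl to 1,2,2-trimethylpropyl

This account rests on a few compounds, and the source may have more. Where it says the series, first, only, none or still open, it means among the compounds named here.

Measured so far:
compound 1, `CC(/N=c1\c(O)c(O)\c1=N/Cc1ccc(C#N)cc1Cl)C(C)(C)C`: 180 nM
compound 2, `CC(C)(C)/N=c1\c(O)c(O)\c1=N/Cc1ccc(Cl)cc1Cl`: 1300 nM

In a functional assay for inhibition, with Rattus norvegicus as the target (on this read-out lower numbers stand for stronger inhibition and higher numbers for weaker inhibition), compound 2 gives 1300 nM, the highest of the two numbers in hand. Compound 1 gives 180 nM in this assay, a gap beyond the usual scatter; the two compounds differ in more than one place, so the numbers alone are what they show.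

Compound 3, `CC(/N=c1\c(O)c(O)\c1=N/Cc1ccc(Cl)cc1Cl)C(C)(C)C`, is still to be measured in this assay. Against compound 2 the change is 1,2,2-trimethylpropyl in place of tert-butyl on a double-bonded nitrogen. Going by the values given here, no pair differing in this one group has been measured, so the size of the step is open. Compound 1 carries the same 1,2,2-trimethylpropyl group and sits at 180 nM, which points toward a lower number for compound 3. A moderate step from a 2.6-fold lower number from compound 2 to compound 3 (0.41 log units; beyond the scatter) is expected, plausibly beyond the scatter but not certainly. Compound 3 is estimated at 500 nM, with a range from 150 nM to 1600 nM.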

Compound 3, half-maximal inhibitory concentration: 340 nM
Estimate against measurement, compound 3: 1.5-fold (0.17 log units) above; the range from low to high includes it.
By their numbers in this assay, from the lowest: compounds 1 and 3 (each within the scatter of the next); then compound 2.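

In this assay, going by these compounds alone, 1,2,2-trimethylpropyl in place of tert-butyl on a double-bonded nitrogen gives the first single-place reading at this position (a 3.8-fold lower number from compound 2 to compound 3 (0.58 log units; beyond the scatter)), and the step lies beyond the scatter. With 1,2,2-trimethylpropyl held constant, chloro in place of cyano on an aromatic carbon does not separate the two compounds (a 1.9-fold higher number from compound 1 to compound 3 (0.28 log units; within the scatter)), as that step stays within the scatter. Nothing in hand offers a reason for either step.

Among the compounds shown, the tert-butyl partner of compound 1 is absent, so whether the step on the nitrogen carries over with cyano remains open. Also open, as far as these compounds go, are how a longer chain or a cyclohexyl group would read on that nitrogen, and how a methoxy group or a carboxylic acid would compare with chloro and cyano on that aromatic carbon.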